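This account rests on a few compounds, and the source may have more. Where it says the series, first, only, none or still open, it means among the compounds named here.

Measured in a functional assay on PC-9 cells (Homo sapiens) for inhibition, read by MTT assay, with a stated time of 48 h, tested at 10 uM; a lower number here means less inhibition, a higher number more inhibition at the concentration tested (going by the name of the read-out):
- compound 1 `COc1cc(NC(=O)Nc2cc(Nc3ccc(C(C)(C)C)cc3)ncn2)cc(OC)c1`: 74.1%
- compound 2 `CCc1ccc(Nc2cc(NC(=O)Nc3cc(OC)cc(OC)c3)ncn2)cc1`: 78%
- compound 3 `COc1cc(NC(=O)Nc2cc(Nc3ccc(C)c(F)c3)ncn2)cc(OC)c1`: 77.5%

Compound 3 stands second highest of the three numbers in this assay; its nearest neighbour is compound 2, a number 0.5 percentage points lower from compound 2 to compound 3 (within the scatter), and its furthest is compound 1, a number 3.4 percentage points higher from compound 1 to compound 3 (within the scatter), both steps lying within the scatter.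

Compound 4 `CCc1cccc(Nc2cc(NC(=O)Nc3cc(OC)cc(OC)c3)ncn2)c1` differs from compound 3 in one place: 3-ethylphenyl in place of 3-fluoro-4-methylphenyl on a nitrogen on an aromatic ring.

Within the data shown here, two measured steps bear on this change, since each replaces the aryl group on the same nitrogen: a number 3.4 percentage points higher from compound 1 to compound 3 (within the scatter) and a number 0.5 percentage points lower from compound 2 to compound 3 (within the scatter). The remaining step, a number 3.9 percentage points higher from compound 1 to compound 2 (within the scatter), varied the group on that same ring and also stayed within the scatter. Across all three, changing this aryl substituent has produced no step beyond the scatter, so no step beyond the scatter is expected here either: a number 1.5 percentage points lower from compound 3 to compound 4 (within the scatter). Compound 4 is therefore estimated to give 76% in this assay, with an expected range from 65% to 86%.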

Compound 4, a percentage reported as inhibition, at one concentration (the size of the read-out at that concentration, not a potency): 82.1%
The estimate for compound 4 lay 6.1 percentage points below the measured number, and the stated range covers the measured number.
By their numbers in this assay, from the lowest: compounds 1, 3, 2 and 4 (each within the scatter of the next).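

With 3-ethylphenyl in place of 4-ethylphenyl on the nitrogen, this assay gives a number 4.1 percentage points higher from compound 2 to compound 4 (within the scatter) and so does not separate these two ethylphenyl groups. The same group gives a number 4.6 percentage points higher from compound 3 to compound 4 (within the scatter) against 3-fluoro-4-methylphenyl and a number 8 percentage points higher from compound 1 to compound 4 (within the scatter) against 4-(tert-butyl)phenyl, so even the largest step in the series leaves this aryl position without a resolved preference. No measurement shown explains these steps. Open, on these data alone, is whether an amine, a carboxylic acid or a chain longer than ethyl on this aryl ring would give a step beyond the scatter. Potency also stays open, as all numbers come from a single concentration.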